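Trading chloro for methoxy on a chalcone amide scaffold

A few compounds are considered here, and "the series" means these few. Any claim that something is new, unique, unknown or untested is made for them only; others in the source may bear on it.

Three compounds were tested in a functional assay on the whole organism (strain albino) for inhibition, with Rattus norvegicus as the target, read by paw edema, with stated times of 30 min and 4 h, at a dose of 100 mg/kg by the oral route; on this read-out higher numbers stand for more inhibition at the one dose given (going by the name of the read-out) and lower numbers for less inhibition. Compound 1 `O=C(CO[N+](=O)[O-])Nc1ccc(C(=O)/C=C/c2ccc(Cl)cc2)cc1` gives 67%. Compound 2 `COc1ccc(/C=C/C(=O)c2ccc(NC(=O)CO[N+](=O)[O-])cc2)cc1` gives 51% in this assay. Compound 3 `C/C(=N/O)c1ccc(OCC(=O)Nc2ccc(C(=O)/C=C/c3ccc(Cl)cc3)cc2)cc1` gives 55% in this assay. Compound 4 `COc1ccc(/C=C/C(=O)c2ccc(NC(=O)COc3ccc(/C(C)=N\O)cc3)cc2)cc1` has not yet been tested.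

Compound 2 differs from compound 1 in one place: methoxy in place of chloro on an aromatic carbon. That change is the one listed step of its kind, and it gave a number 16 percentage points lower from compound 1 to compound 2 (beyond the scatter). Compound 3 differs from compound 1 elsewhere, in the side chain of the amide: a group of 10 heavy atoms (8 carbon, 1 nitrogen, 1 oxygen; one six-membered aromatic ring of carbon only) in place of a group of 3 heavy atoms (1 nitrogen, 2 oxygen; no ring), on an oxygen on a saturated carbon. That change gave a number 12 percentage points lower from compound 1 to compound 3 (beyond the scatter), so compound 3 stands between the other two, though its gap to compound 2 is within the usual scatter.

Compound 4 relates to compound 3 exactly as compound 2 relates to compound 1: methoxy in place of chloro on an aromatic carbon. The place is described in the same words both times, so this is the same change made on the two different cores, and among the compounds shown it occurs twice. Within the data shown here, only one measured example of the change exists, so the expectation rests on that one step. Compound 4 is expected to give 41%, with a likely range from 28% to 54%, in this assay. Among the measured compounds shown here, this estimate means a step of a number 14 percentage points lower from compound 3 to compound 4 (beyond the scatter), which matches in direction and size the step seen from compound 1 to compound 2, because a number 16 percentage points lower from compound 1 to compound 2 (beyond the scatter) is the only guide available for this change.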

Compound 4, a percentage reported as inhibition, in the whole organism at one dose (the size of the read-out at that dose, not a potency): 42%
Beside the measured number, compound 4's estimate is 1 percentage points below it; the range from low to high includes it.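

In this assay, the swap of chloro for methoxy on the core of compound 3 gave a number 13 percentage points lower from compound 3 to compound 4 (beyond the scatter), and set beside the earlier step, the change carried over from one core to the other with little difference: the same change on two cores in this assay, a number 16 percentage points lower (beyond the scatter) from compound 1 to compound 2 and a number 13 percentage points lower (beyond the scatter) from compound 3 to compound 4, 3 percentage points apart, within the scatter of two such steps

The exchange of the side chain, read this time on the two methoxy compounds, gave a number 9 percentage points lower from compound 2 to compound 4 (within the scatter), which taken alone cannot be told from scatter, yet it does not differ from the same exchange on the two chloro compounds: the same change on two cores in this assay, a number 12 percentage points lower (beyond the scatter) from compound 1 to compound 3 and a number 9 percentage points lower (within the scatter) from compound 2 to compound 4, 3 percentage points apart, within the scatter of two such steps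

Within these four compounds, then, each of the two changes shifted the read-out by much the same amount whichever form the other part took, but this rests on only two cores and a single dose, so it is no general rule for the series and does not explain why the numbers fall.

What the compounds shown leave open is whether the same carry-over holds for other groups at this place on the ring, since only chloro and methoxy appear there, and a fluoro, a methyl or an amine might behave differently. Going by these compounds, it is also open whether the pattern would survive a longer chain in the side chain of the amide.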